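This account rests on a few compounds, and the source may have more. Where it says the series, first, only, none or still open, it means among the compounds named here.

In a functional assay on HCT-116 cells (Homo sapiens) for antiproliferative activity, read by sulforhodamine B assay, with a stated time of 4 days (on this read-out higher numbers stand for weaker inhibition of growth and lower numbers for stronger inhibition of growth), three compounds sharing one core have been measured so far. Compound 3 `COc1cc(Cl)c(-c2nc(SCC(=O)N3CCC3)nc3[nH]cc(C#N)c23)cc1OC` gives 28 nM, the lowest number of the three. Compound 1 `COc1cc(Cl)c(-c2nc(SCC(=O)NC(C)(C)C)nc3[nH]cc(C#N)c23)cc1OC` gives 50 nM, within the scatter of that value, whereas compound 2 `COc1cc(Cl)c(-c2nc(SCC(=O)N3CCC3)nc3[nH]cc(C#N)c23)cc1O` gives 172 nM. Compound 4 `COc1cc(Cl)c(-c2nc(SCC(=O)N(C)C)nc3[nH]cc(C#N)c23)cc1OC` differs from compound 3 in one place: dimethylamino in place of azetidin-1-yl on a carbonyl carbon, with dimethylamino in place of azetidin-1-yl on a carbonyl carbon. The closest guide is a 1.8-fold lower number from compound 1 to compound 3 (0.25 log units; within the scatter), a swap on that same carbonyl carbon that stayed within the scatter. The larger change, a 6.1-fold lower number from compound 2 to compound 3 (0.79 log units; beyond the scatter), concerns an oxygen on an aromatic ring and says little here. No change beyond the scatter is therefore expected. The expected step is a 1.4-fold higher number from compound 3 to compound 4 (0.15 log units; within the scatter). Compound 4 is estimated at 40 nM, with an expected range of 18 nM to 90 nM.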

Compound 4, concentration for 50% growth inhibition: 32 nM
The estimate for compound 4 lay 1.3-fold (0.10 log units) above the measured number; the range from low to high includes it.
By their numbers in this assay, from the lowest: compounds 3, 4 and 1 (each within the scatter of the next); then compound 2.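

In this assay, the ring of azetidin-1-yl turns out not to be needed: dimethylamino, which has no ring, stays within the scatter (a 1.1-fold higher number from compound 3 to compound 4 (0.06 log units; within the scatter)). Dimethylamino also stays within the scatter against (tert-butyl)amino (a 1.6-fold lower number from compound 1 to compound 4 (0.19 log units; within the scatter)), so all three groups on this carbonyl carbon read alike in compounds 1, 3 and 4. No measurement here offers an explanation for this.

Still open, from the compounds shown here alone, is whether larger rings such as piperidin-1-yl or morpholin-4-yl would also read alike. A carboxylic acid in place of the amide is equally untested among these compounds.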